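This account rests on a few compounds, and the source may have more. Where it says the series, first, only, none or still open, it means among the compounds named here.

The measured compounds:
compound 1, `COC(=O)c1cc(-c2csc(N/N=C/c3ccc(Cl)cc3Cl)n2)ccc1OCc1ccccc1`, 58.9%
compound 2, `Cc1ccc(-c2csc(N/N=C/c3cccs3)n2)cc1`, 79.6%

Both were tested in a functional assay, read by spectrophotometry, with a stated time of 15 min, tested at 20 ug/mL; on this read-out lower numbers stand for a weaker effect and higher numbers for a stronger effect at the one concentration tested. Compound 2 stands highest of the two numbers: in this assay compound 2 reaches 79.6%, while compound 1 gives 58.9%, a gap that lies beyond the scatter of repeated measurements. Within the data shown here, the two compounds differ in more than one place, so no single step between them has been worked out.

Compound 3, `Fc1ccc(-c2csc(N/N=C/c3cccs3)n2)cc1`, has not yet been measured. It differs from compound 2 in one place: fluoro in place of methyl on an aromatic carbon. A methyl leaves and a fluoro enters, on an aromatic carbon of a six-membered aromatic ring of carbon only. Among the measured compounds shown here, with no measured step of this kind to lean on, the expectation is a small change at most, none beyond the scatter. The expected step is a number 7.6 percentage points lower from compound 2 to compound 3 (within the scatter). The estimated value for compound 3 is 72%, with a range from 55% to 88%.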

Compound 3, a percentage reported as inhibition, at one concentration (the size of the read-out at that concentration, not a potency): 84.2%
Compound 3: the middle estimate sits 12.2 percentage points below what was measured; measured number inside the range.
By their numbers in this assay, from the lowest: compound 1; then compounds 2 and 3 (each within the scatter of the next).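

Among these compounds, putting fluoro in place of methyl on an aromatic carbon, para to a large group, gives the first single-place step in this set: in this assay it is a number 4.6 percentage points higher from compound 2 to compound 3 (within the scatter). At this position, then, this read-out does not separate the two groups, and a methyl is not needed to keep the number in the range of compound 2. No measurement at hand offers an explanation for this result.

As far as these compounds go, the two groups compared here are both single atoms attached to the ring, so it remains open whether something quite different at the same carbon, such as an amine, a carboxylic acid or a longer chain, would keep the number there. From the compounds shown here alone, it is also open whether the same exchange would act alike on the core of compound 1.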